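The source may hold more compounds than are shown below. What is called first, only, known or untested is meant among the compounds shown, and "the series" means these compounds.

Working notes on the aryl carbamate series.

The three measured compounds share one core and differ only in the carbamate oxygen substituent. Compound 1 `COc1ccc(OC(=O)Nc2ccc([Se]C#N)cc2)cc1` carries a methoxy-substituted aryl carbamate; in a functional assay on HTB-54 cells (Homo sapiens) for cytotoxicity, read by MTT assay, with a stated time of 72 h (on this read-out lower numbers stand for stronger inhibition of growth and higher numbers for weaker inhibition of growth), compound 1 gives 48500 nM. Compound 2 `CCCCOC(=O)Nc1ccc([Se]C#N)cc1`, the butyl carbamate, gives 43400 nM, and compound 3 `CC(C)COC(=O)Nc1ccc([Se]C#N)cc1`, the isobutyl carbamate, gives 51200 nM. Among these three numbers compound 1 stands second highest, but its gaps to compound 3 and to compound 2 both fall within the scatter, so no order among the three can be read. Among the compounds with values here, the single step between neighbours, a 1.2-fold higher number from compound 2 to compound 3 (0.07 log units; within the scatter), also stays within the scatter.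

Compound 4 `N#C[Se]c1ccc(NC(=O)Oc2ccc(Cl)cc2)cc1` is the next aryl carbamate: chloro in place of methoxy on an aromatic carbon. Within the data shown here, no measured step touches this aromatic position; the only step available concerns the alkyl chain of the carbamate and was flat, and the aryl and alkyl carbamates themselves sit within the scatter of one another. On this basis no movement beyond the scatter is expected in this assay for compound 4. The step expected from this change, a 1.0-fold lower number from compound 1 to compound 4 (0.00 log units; within the scatter), is accordingly small. Compound 4 is estimated at 48000 nM, with a range from 24000 nM to 96000 nM.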

Compound 4, concentration for total growth inhibition: 41400 nM
For compound 4 the middle estimate is 1.2-fold (0.06 log units) above the measured one; the measured number falls inside the stated range.
By their numbers in this assay, from the lowest: compounds 4, 2, 1 and 3 (each within the scatter of the next).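

In this assay, chloro in place of methoxy on an aromatic carbon, para to a large group, gives a 1.2-fold lower number from compound 1 to compound 4 (0.07 log units; within the scatter), so this change stays within the scatter. The earlier step concerned only the saturated chain of the carbamate, whereas this pair shows that the aromatic position can also carry either of these two groups with no separable difference in the read-out, even though the methoxy brings a hydrogen-bond acceptor and the chloro brings none. No supporting data on either group are available to interpret this flat result, and a single pair sets no trend for the position.

Going by these compounds, whether an amine or a carboxylic acid on this aromatic carbon would give a step beyond the scatter remains open, as does the outcome of a longer chain on the carbamate oxygen. With each of the four compounds within the scatter of the next, the series shown does not yet identify any change that separates one carbamate from another in this read-out.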